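The source may hold more compounds than are shown below. What is called first, only, known or untested is meant among the compounds shown, and "the series" means these compounds.

Three compounds share one core and differ only in the group on one aromatic carbon. Compound 1 `CSc1coc(C(=O)CCCCCCc2ccccc2)n1` carries a methylsulfanyl group there and gives, in an assay on isolated protein for inhibition of Fatty-acid amide hydrolase 1 (Rattus norvegicus) (on this read-out lower numbers stand for stronger inhibition and higher numbers for weaker inhibition), 29 nM. Compound 2 `O=Cc1coc(C(=O)CCCCCCc2ccccc2)n1` carries a formyl group and gives in this assay 55 nM. Compound 3 `CC(=O)c1coc(C(=O)CCCCCCc2ccccc2)n1` carries an acetyl group and gives in this assay 2 nM, the lowest of the three numbers: a 15-fold lower number from compound 1 to compound 3 (1.16 log units; beyond the scatter) and a 28-fold lower number from compound 2 to compound 3 (1.44 log units; beyond the scatter), both beyond the scatter, while a 1.9-fold higher number from compound 1 to compound 2 (0.28 log units; within the scatter) stays within it.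

Compound 4 `O=C(CCCCCCc1ccccc1)c1nc(C(=O)C(F)(F)F)co1` is not yet measured. It differs from compound 3 by trifluoromethyl in place of methyl on a carbonyl carbon. Going by the values given here, the one measured step that touches this same carbonyl carbon is a 28-fold lower number from compound 2 to compound 3 (1.44 log units; beyond the scatter), a large lowering. The other steps change the whole group on the aromatic carbon and bear less directly. A further change at this carbon is therefore expected to move the number again, and compound 4 is expected to show a 3.3-fold lower number from compound 3 to compound 4 (0.52 log units; beyond the scatter), landing at 0.6 nM with a range from 0.1 nM to 4 nM.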

Compound 4, inhibition constant: 470 nM
Beside the measured number, compound 4's estimate is 780-fold (2.89 log units) below it; measured number outside the range, above it.
By their numbers in this assay, from the lowest: compound 3; then compounds 1 and 2 (each within the scatter of the next); then compound 4.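

Trifluoromethyl in place of methyl on this carbonyl carbon moves the number in this assay sharply upward (a 240-fold higher number from compound 3 to compound 4 (2.37 log units; beyond the scatter)), so the lowering seen on going from hydrogen to methyl there does not continue with this group. Compound 4 also sits above both other compounds, whether compared with the formyl compound (an 8.5-fold higher number from compound 2 to compound 4 (0.93 log units; beyond the scatter)) or with the methylsulfanyl compound (a 16-fold higher number from compound 1 to compound 4 (1.21 log units; beyond the scatter)), making it the weakest inhibitor of the four. Nothing available explains this reversal.

The compounds shown leave open how the number responds to other groups on this carbonyl carbon, such as ethyl or fluoromethyl. They also leave open what a carboxylic acid or an amide would give on the aromatic carbon.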